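Lengthening a chain on an amidoxime antiproliferative

A few compounds are considered here, and "the series" means these few. Any claim that something is new, unique, unknown or untested is made for them only; others in the source may bear on it.

Measured compounds:
Compound 1 `CCCCNCC(=O)Nc1ccc(/C(N)=N/O)cc1` gives 83000 nM in a functional assay on HCT-116 cells (Homo sapiens) for antiproliferative activity, read by WST assay, with a stated time of 72 h; a lower number here means that less compound is needed, a higher number that more compound is needed for the effect.
Compound 2 `CCCCCCNCCC(=O)Nc1ccc(/C(N)=N/O)cc1` gives 193000 nM.
Compound 3 `CCCCNC(=O)Nc1ccc(/C(N)=N/O)cc1` gives 186000 nM.

Among these three, compound 1 has the lowest number, so the least of it is needed. Its nearest neighbour is compound 3, reached by a 2.2-fold higher number from compound 1 to compound 3 (0.35 log units; beyond the scatter), and compound 2 stands a little further off again.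

Compound 4 `CCCCCCNCC(=O)Nc1ccc(/C(N)=N/O)cc1` is the unmeasured compound. It differs from compound 1 by ethyl in place of hydrogen on a saturated chain carbon, four bonds along the chain from an amine nitrogen. Within the data shown here, no measured step isolates this change. Among the measured compounds shown here, the only measured step, from compound 1 to compound 3, concerns the carbonyl side and is modest. Compound 2 also carries a longer chain than compound 1 but differs in more than one place, so its higher number can only hint that a longer chain does not help. With so little to go on, the expectation is a small rise or no change beyond the scatter, and the step from compound 1 to compound 4 is estimated as a 1.3-fold higher number from compound 1 to compound 4 (0.12 log units; within the scatter). Compound 4 is therefore expected to give about 110000 nM, between 50000 nM and 250000 nM.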

Compound 4, half-maximal effective concentration: 124000 nM
Compound 4: the middle estimate sits 1.1-fold (0.05 log units) below what was measured, within the range that was stated.
By their numbers in this assay, from the lowest: compounds 1, 4, 3 and 2 (each within the scatter of the next, the first and the last beyond it).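

In this assay, ethyl in place of hydrogen on a saturated chain carbon, four bonds along the chain from an amine nitrogen, is now seen as a single change, and it gives a 1.5-fold higher number from compound 1 to compound 4 (0.17 log units; within the scatter). Taken alone, this lengthening of the chain therefore does not clearly separate the two compounds, which is more direct information than the earlier compounds could give, as none of them isolated this change. Nothing measured here explains this result.

On these data alone, whether a longer chain at the same place would give a step beyond the scatter remains open. So does whether a chain ending in a carboxylic acid or a phenyl ring would lower the number in this assay.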